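This account rests on a few compounds, and the source may have more. Where it says the series, first, only, none or still open, it means among the compounds named here.

All four compounds share one core, each carrying a different aromatic ring at the far end of the chain. In an ADME assay on cells (Epithelial cell, Homo sapiens) for cytotoxicity, read by MTT assay, with a stated time of 24 h (on this read-out higher numbers stand for lower toxicity in this test and lower numbers for higher toxicity in this test), compound 1 `CC(=O)OC[C@H]1O[C@@H](CC(=O)/C=C/c2ccc([N+](=O)[O-])s2)[C@H](OC(C)=O)[C@@H](OC(C)=O)[C@@H]1OC(C)=O` gives "not determined" (no result reported), so no number stands for it. In this assay compound 3 `CC(=O)OC[C@H]1O[C@@H](CC(=O)/C=C/c2ccc([N+](=O)[O-])cc2)[C@H](OC(C)=O)[C@@H](OC(C)=O)[C@@H]1OC(C)=O` gives "not determined" (no result reported), so no number stands for it either. Among the compounds with values here, compound 2 `CC(=O)OC[C@H]1O[C@@H](CC(=O)/C=C/c2ccc(Cl)c(Cl)c2)[C@H](OC(C)=O)[C@@H](OC(C)=O)[C@@H]1OC(C)=O` gives 25.8 nM in this assay, the only number in this set. Compound 3 therefore stands nowhere on the numbers shown; its own toxicity is simply unknown. Compound 4 `CC(=O)OC[C@H]1O[C@@H](CC(=O)/C=C/c2ccc(C)cc2)[C@H](OC(C)=O)[C@@H](OC(C)=O)[C@@H]1OC(C)=O` differs from compound 3 in one place: methyl in place of nitro on an aromatic carbon. Within the data shown here, no measured pair shows what this change does, so the step from compound 3 to compound 4 is expected to stay within the scatter, in no firm direction. Among the measured compounds shown here, the only anchor is compound 2 at 25.8 nM. Compound 4 is expected to give 30 nM, in a range from 8 nM to 110 nM.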

Compound 4, half-maximal cytotoxic concentration: 3.18 nM
Estimate against measurement, compound 4: 9.4-fold (0.97 log units) above, and the stated range ends above it.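

Replacing the ring at the far end of the chain changes the result in this assay: the swap gives an 8.1-fold lower number from compound 2 to compound 4 (0.91 log units; beyond the scatter), so 4-methylphenyl goes with higher toxicity in this test than 3,4-dichlorophenyl. Within the data shown here, this is the first readable step at this position, though methyl in place of nitro still cannot be read, as compound 3 has no number. Nothing measured here accounts for the step. As far as these compounds go, it remains open how a ring carrying an amine, a carboxylic acid or a longer chain would compare with 4-methylphenyl.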